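Shortening the chain of a weak inhibitor

The source may report more compounds than this note shows. Statements on the series, on what has been measured and on what is new or still open speak of the compounds shown alone.

For the measured compounds named here, in a functional assay on A549 cells (Homo sapiens) for antiproliferative activity, read by CCK-8 assay, with a stated time of 48 h (a lower number here means a stronger inhibitor, a higher number a weaker inhibitor), compound 2 `O=C(CCCCCC(=O)NCCNc1nonc1/C(=N/O)Nc1ccc(F)c(Br)c1)NO` gives 40700 nM, the only exact number so far. Compound 1 `O=C(CCCCC(=O)NCCNc1nonc1/C(=N/O)Nc1ccc(F)c(Br)c1)NO` gives > 100000 nM, which is a limit of the assay and not a number. Compound 3 `O=C(CCCC(=O)NCCNc1nonc1/C(=N/O)Nc1ccc(F)c(Br)c1)NO` differs from compound 2 by hydroxycarbamoyl in place of 2-(hydroxycarbamoyl)ethyl on a saturated chain carbon, three bonds along the chain from a carbonyl carbon, with hydroxycarbamoyl in place of 2-(hydroxycarbamoyl)ethyl. Going by the values given here, the one measured step bearing on this is an at least 2.4-fold lower number from compound 1 to compound 2 (0.39 log units; beyond the scatter), beyond the scatter, where the longer chain gave the lower number. A shorter chain should therefore raise the number in this assay. The expected step is a 2.9-fold higher number from compound 2 to compound 3 (0.47 log units; beyond the scatter). For compound 3 the estimated value is 120000 nM, within an expected range of 50000 nM to 300000 nM.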

Compound 3, half-maximal inhibitory concentration: > 100000 nM
Compound 3 ended at the assay's limit; the forecaster's own chance of this, stated with the estimate: 65%; the middle value is on the limit's open side.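

In this assay, shortening the chain gives an at least 2.4-fold higher number from compound 2 to compound 3 (0.39 log units; beyond the scatter), so compound 2 now has the lowest number of the three, with both shorter chains on the weaker side. The comparison of compound 1 with compound 3 cannot be read, since each is a limit and not a number: the limit of > 100000 nM in this assay, at which 2 of the 3 values shown sit.

As far as these compounds go, whether a longer chain than that of compound 2 would lower the number further remains open. So does whether a carboxylic acid in place of hydroxycarbamoyl would hold the number of compound 2.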